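The source may report more compounds than this note shows. Statements on the series, on what has been measured and on what is new or still open speak of the compounds shown alone.

Compound 1, `Nc1cccc(/C=C/c2ccccc2)c1`, and compound 2, `Oc1ccc(/C=C/c2ccccc2O)cc1`, were both tested in a functional assay on MCF7 cells (Homo sapiens) for inhibition, read by MTT assay, with a stated time of 2 days; on this read-out higher numbers stand for weaker inhibition and lower numbers for stronger inhibition. In that assay compound 2 gives 21 ug/mL, a number that sits within the usual scatter of compound 1's 14 ug/mL, so the two cannot be told apart. Compound 3, `Nc1ccccc1/C=C/c1ccc(O)cc1`, differs from compound 2 by amino in place of hydroxy on an aromatic carbon. Among the compounds with values here, no measured pair shows this exchange, and the two numbers at hand suggest no step beyond the scatter in either direction. Compound 3 is therefore expected to give 17 ug/mL, with a range of 7 ug/mL to 45 ug/mL, a step from compound 2 to compound 3 of a 1.2-fold lower number from compound 2 to compound 3 (0.09 log units; within the scatter).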

Compound 3, half-maximal inhibitory concentration: 79 ug/mL
Estimate against measurement, compound 3: 4.6-fold (0.67 log units) below, and the stated range ends below it.
By their numbers in this assay, from the lowest: compounds 1 and 2 (each within the scatter of the next); then compound 3.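

In this assay, within the data shown here, amino in place of hydroxy on an aromatic carbon, ortho to a group of 9 heavy atoms, gives the first step beyond the scatter, a 3.8-fold higher number from compound 2 to compound 3 (0.58 log units; beyond the scatter), so inhibition is weaker with amino at this position. The two groups differ here even though their counts of heavy atoms, hydrogen-bond donors and hydrogen-bond acceptors are the same. Nothing at hand accounts for the step.

As far as these compounds go, whether a methoxy group or an acetamide at this position would match compound 2 or compound 3 stays open. So does whether this exchange elsewhere on the shared core would give a similar step.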